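Ethoxy for fluoro on the carboxy core

This account rests on a few compounds, and the source may have more. Where it says the series, first, only, none or still open, it means among the compounds named here.

Compound 1 `Cc1c(C(=O)Nc2c(F)cc(-c3cccc(F)c3)cc2F)nc2ccc(F)cc2c1O` is the reference of the set. In a functional assay on A-375 cells (Homo sapiens) for antiproliferative activity, read by MTT assay, with a stated time of 24 h, tested at 0.02 ug/mL (a higher number here means a stronger effect of the compound at the concentration tested, a lower number a weaker effect), compound 1 gives -0.13%. Compound 2 `CCOc1ccc2nc(C(=O)Nc3c(F)cc(-c4cccc(F)c4)cc3F)c(C)c(O)c2c1` carries the change (ethoxy in place of fluoro on an aromatic carbon), and the step is a number 0.8 percentage points higher from compound 1 to compound 2 (within the scatter). In this assay compound 2 gives 0.68%. Compound 3 `Cc1c(C(=O)Nc2c(F)cc(-c3cccc(F)c3)cc2F)nc2ccc(F)cc2c1C(=O)O` gives -0.22% in this assay, and the step is a number 0.1 percentage points lower from compound 1 to compound 3 (within the scatter). Going by the values given here, all three numbers sit near zero, and no pair is separated beyond the scatter.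

Compound 4 `CCOc1ccc2nc(C(=O)Nc3c(F)cc(-c4cccc(F)c4)cc3F)c(C)c(C(=O)O)c2c1` is not yet measured. It differs from compound 3 by ethoxy in place of fluoro on an aromatic carbon. The place is the same word for word as for the change from compound 1 to compound 2, so this is the same change, now on the core of compound 3; the two cores differ by carboxy in place of hydroxy on an aromatic carbon.

Given that the step from compound 1 to compound 2 was a number 0.8 percentage points higher from compound 1 to compound 2 (within the scatter) and the whole set is flat, the expected step is a number 0.8 percentage points higher from compound 3 to compound 4 (within the scatter). Compound 4 is thus estimated at 0.6%, with a range from -4% to 5%.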

Compound 4, a percentage reported as inhibition, at one concentration (the size of the read-out at that concentration, not a potency): 1.02%
Beside the measured number, compound 4's estimate is 0.4 percentage points below it; measured number inside the range.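

In this assay, ethoxy in place of fluoro on the carboxy core of compound 3 gives a number 1.2 percentage points higher from compound 3 to compound 4 (within the scatter), and this matches the step on the core of compound 1: the same change on two cores in this assay, a number 0.8 percentage points higher (within the scatter) from compound 1 to compound 2 and a number 1.2 percentage points higher (within the scatter) from compound 3 to compound 4, 0.4 percentage points apart, within the scatter of two such steps. Carboxy in place of hydroxy, read on the ethoxy core, gives a number 0.3 percentage points higher from compound 2 to compound 4 (within the scatter), and it too matches its earlier step: the same change on two cores in this assay, a number 0.1 percentage points lower (within the scatter) from compound 1 to compound 3 and a number 0.3 percentage points higher (within the scatter) from compound 2 to compound 4, 0.4 percentage points apart, within the scatter of two such steps. Going by these compounds alone, both changes therefore behave alike on the two cores, but all four compounds sit near zero in this assay and every step lies within the scatter, so this shows only that neither change produces a readable effect here, not that either would carry over unchanged on a compound with a clear effect.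

The compounds shown leave open whether another group in the ethoxy place, such as an amine or a longer chain, or a nitrile in the carboxy place, would move the read-out beyond the scatter. They also leave open how the four compounds compare at a higher concentration.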